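The source may report more compounds than this note shows. Statements on the series, on what has been measured and on what is new or still open speak of the compounds shown alone.

Measured in an ADME assay on HepG2 2.2.15 cells (Homo sapiens) for cytotoxicity, read by MTT assay, with a stated time of 8 days (a lower number here means that less compound is tolerated, a higher number that more compound is tolerated), all values being limits of the assay:
- compound 1 `CC(=O)Nc1ccc(-c2nn(Cc3ccc(C#N)cc3)c(=O)c3ccccc23)c(F)n1`: > 100000 nM
- compound 2 `O=c1c(CO)cc(-c2ccc(F)nc2F)nn1Cc1ccc(Cl)cc1`: > 100000 nM
- compound 3 `COC(=O)C1=C(C)NC(c2ncc(F)cc2F)=N[C@H]1c1ccc(F)cc1Cl`: > 5000 nM

Compound 1 gives only a limit and no number, and it stands at the limit of > 100000 nM in this assay, at which 2 of the 3 values shown sit. With limits alone, the compounds cannot be ranked.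

Compound 4 `CNc1ccc(-c2nn(Cc3ccc(C#N)cc3)c(=O)c3ccccc23)c(F)n1` carries methyl in place of acetyl on a nitrogen on an aromatic ring, the change from acetamido to methylamino: methyl in place of acetyl on a nitrogen on an aromatic ring. Among the compounds with values here, no measured step in this assay covers this change, so no step beyond the scatter is expected, with any small move more likely downward. The expected change is an at least 1.4-fold lower number from compound 1 to compound 4 (0.15 log units; that floor lies within the scatter). For compound 4 the estimated value is 70000 nM, with an expected range of 25000 nM to 150000 nM.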

Compound 4, half-maximal cytotoxic concentration: > 100000 nM
Compound 4: only a limit was reported; the forecaster's own chance of this, stated with the estimate: 55%; middle value at least 1.4-fold (0.15 log units) away from the limit.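

Compound 1 and compound 4 both give only a limit in this assay, so no step can be read between them. As far as these compounds go, whether the change from acetamido to methylamino shifts the half-maximal cytotoxic concentration at all remains open.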